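A few compounds are considered here, and "the series" means these few. Any claim that something is new, unique, unknown or untested is made for them only; others in the source may bear on it.

Series notes. Compound 1 `CC(C)N1Cc2cc(OCc3cccc(-c4ccc(Cl)c(C(=O)O)c4)c3)ccc2C1=O` reaches 88.1% in an assay on HEK293 cells for positive allosteric modulation of metabotropic glutamate receptor 2 (Rattus norvegicus), read by thallium flux; a lower number here means a smaller maximal response, a higher number a larger maximal response. Compound 3 `O=C(O)c1cc(-c2cccc(COc3ccc4c(c3)CCN(C3CCCC3)C4=O)c2)ccc1Cl` reaches 66.9% in this assay. Compound 2 `CCCN1Cc2cc(OCc3cccc(-c4ccc(Cl)c(C(=O)O)c4)c3)ccc2C1=O` gives "not determined" (no result reported) in this assay: no result was reported for it, so its own standing in the series rests on nothing measured. Compound 4 `O=C(O)c1cc(-c2cccc(COc3ccc4c(c3)CN(C3CCC3)C4=O)c2)ccc1Cl` is the next member to be measured. It differs from compound 2 in a single place: cyclobutyl in place of propyl on an amide-type nitrogen in a ring. Among the measured compounds shown here, no measured pair shows this change on its own, and compound 3 differs from compound 1 in more than the group on the amide-type nitrogen, so the two values of compound 1 and compound 3 cannot be read as a step for this change. With no starting number for compound 2, the expected step in this assay is taken as small, of either sign, and probably not beyond the scatter, with the values of compound 1 and compound 3 bracketing what a cyclobutyl member is expected to give. Compound 4 is expected to reach 78%, within 62% to 94%.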

Compound 4, largest response reached (Emax), in percent of the reference or control that the assay uses: 90.3%
The estimate for compound 4 lay 12.3 percentage points below the measured number; the measured number falls inside the stated range.
By their numbers in this assay, from the lowest: compound 3; then compounds 1 and 4 (each within the scatter of the next).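

In this assay, among the compounds shown here, the change to cyclobutyl in place of isopropyl on the amide-type nitrogen in a ring gives the first readable step at this position, a number 2.2 percentage points higher from compound 1 to compound 4 (within the scatter). On this core, the four-membered ring of carbon and the branched isopropyl therefore cannot be told apart in largest response reached. The compounds shown offer no evidence on the reason for this result.

Compound 2 has no number, so its step to compound 4 cannot be read, and the comparison of the unbranched propyl chain with cyclobutyl stays unresolved. Also open, as far as these compounds go, is whether the response at this nitrogen holds with a longer chain such as butyl, or with a chain ending in an amine or a carboxylic acid.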